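Replacing the Imidazolyl Group on Compound 1

The source may hold more compounds than are shown below. What is called first, only, known or untested is meant among the compounds shown, and "the series" means these compounds.

Compound 1 `COc1ccccc1OCC1SCCN1C(=O)Cn1ccnc1` was tested in a functional assay on the whole organism for inhibition, with Cavia porcellus as the target (on this read-out higher numbers stand for an effect only at larger amounts of compound and lower numbers for an effect already at smaller amounts), where compound 1 gives 50 mg/kg. Among the measured compounds shown here, only one other compound has a number here: compound 2 `CCOC(=O)CC(=O)N1CCS(=O)(=O)C1COc1ccccc1OC`, which in this assay gives 28 mg/kg. Compound 1 thus shows the higher of the two numbers, but the gap to compound 2 is within the usual scatter of repeated measurements, so the two cannot be told apart on these data.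

Compound 3 `CNC(=O)CC(=O)N1CCSC1COc1ccccc1OC` has not yet been measured. It differs from compound 1 in one place: methylcarbamoyl in place of 1H-imidazol-1-yl on a saturated chain carbon bound to a carbonyl carbon. For the measured compounds named here, no measured pair shows this same change, so its effect can only be anticipated, not read off.

Going by the values given here, the two numbers available lie within the scatter of each other, and no measured step points in either direction. The step from compound 1 to compound 3 is therefore expected to be small, a 1.4-fold lower number from compound 1 to compound 3 (0.15 log units; within the scatter), likely no further than the scatter itself. For compound 3 the estimate in this assay is 35 mg/kg, with a range from 12 mg/kg to 100 mg/kg.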

Compound 3, dose for half-maximal effect: 21 mg/kg
Compound 3: middle estimate off by 1.7-fold (0.22 log units), on the high side; the measured number falls inside the stated range.
By their numbers in this assay, from the lowest: compounds 3, 2 and 1 (each within the scatter of the next, the first and the last beyond it).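

The imidazolyl group turns out not to be required at this position: in this assay, methylcarbamoyl in place of 1H-imidazol-1-yl on a saturated chain carbon bound to a carbonyl carbon gives a 2.4-fold lower number from compound 1 to compound 3 (0.38 log units; beyond the scatter), a modest step, but one that clears the scatter. The five-membered aromatic ring can therefore be given up here for an open group with no ring, and the number does not rise; it falls, with a hydrogen-bond donor now present where the group that left had none. Nothing measured here bears on why the number moved.

This single pair cannot separate the loss of the ring from the gain of the amide hydrogen, since both come with the same change. Open questions are whether dimethylcarbamoyl, which has no amide hydrogen, would keep the lower number of compound 3, and whether a carboxylic acid, an amine or a longer chain in this place would take the number lower still or bring it back up.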